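Swapping the fluorine of compound 3 for a methyl group

The source may hold more compounds than are shown below. What is called first, only, known or untested is meant among the compounds shown, and "the series" means these compounds.

Of the compounds shown here, three sharing one core have been tested in a functional assay on the whole organism for inhibition, with Mythimna separata as the target, with a stated time of 5 days; on this read-out higher numbers stand for an effect only at larger amounts of compound and lower numbers for an effect already at smaller amounts. Compound 1, with structure `CC(C)(C)n1ncc(OCc2nnc(-c3ccc(Br)cc3)o2)c(Cl)c1=O`, gives 21400 nM. Compound 2, with structure `CC(C)(C)n1ncc(OCc2nnc(-c3cc(F)c(F)cc3F)o2)c(Cl)c1=O`, gives 75700 nM. Compound 3, with structure `CC(C)(C)n1ncc(OCc2nnc(-c3ccc(F)cc3)o2)c(Cl)c1=O`, gives 5200 nM, the lowest of the three numbers. The measured steps show how the number moves when the aryl group attached to the five-membered ring is changed: a 4.1-fold lower number from compound 1 to compound 3 (0.61 log units; beyond the scatter), a 3.5-fold higher number from compound 1 to compound 2 (0.55 log units; beyond the scatter) and a 15-fold lower number from compound 2 to compound 3 (1.16 log units; beyond the scatter). Every change on that aryl group so far has moved the number beyond the scatter, and compound 3 stands clearly ahead of its neighbours.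

Compound 4, with structure `Cc1cccc(-c2nnc(COc3cnn(C(C)(C)C)c(=O)c3Cl)o2)c1`, has not yet been measured. It differs from compound 3 by 3-methylphenyl in place of 4-fluorophenyl on an aromatic carbon. For the measured compounds named here, no measured step involves a methyl group, so the direction of this change cannot be read from a matching precedent. What the measured steps do say is that even a single substituent swap on this aryl ring shifted this assay by a modest to large amount, and that compound 3 carries the best substituent seen. Compound 4 is therefore expected to land a modest step above compound 3, that is a 2.3-fold higher number from compound 3 to compound 4 (0.36 log units; beyond the scatter), with an estimated value of 12000 nM and a range from 4000 nM to 40000 nM.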

Compound 4, half-maximal effective concentration: 116000 nM
Compound 4: the middle estimate sits 9.7-fold (0.99 log units) below what was measured, and the stated range ends below it.
By their numbers in this assay, from the lowest: compound 3; then compound 1; then compounds 2 and 4 (each within the scatter of the next).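

In this assay, 3-methylphenyl in place of 4-fluorophenyl gives a 22-fold higher number from compound 3 to compound 4 (1.35 log units; beyond the scatter), so a large shift appears even though the two groups have the same count of heavy atoms and neither carries a hydrogen-bond donor or acceptor. For the compounds shown here, the other two steps place the new group among the earlier ones: there is a 5.4-fold higher number from compound 1 to compound 4 (0.73 log units; beyond the scatter), and there is a 1.5-fold higher number from compound 2 to compound 4 (0.19 log units; within the scatter), so the only aryl group here without a halogen cannot be told apart from 2,4,5-trifluorophenyl in this read-out. Nothing available on these compounds offers an explanation for these shifts.

The step from 4-fluorophenyl to 3-methylphenyl changes both the substituent and its place on the aryl ring, so the compounds shown cannot say how much of the shift belongs to each; 4-methylphenyl and 3-fluorophenyl would pull those two changes apart. As far as these compounds go, it also remains open how this position responds to a substituent of another kind, such as a methoxy group or an amine, on the same aryl ring.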